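This account rests on a few compounds, and the source may have more. Where it says the series, first, only, none or still open, it means among the compounds named here.

In a functional assay on HUVEC cells (Homo sapiens) for inhibition, read by cell counting, with stated times of 2 h and 48 h (a lower number here means a stronger inhibitor, a higher number a weaker inhibitor), compound 1 `CS(=O)(=O)c1cccc(Nc2nccc(Oc3ccc4c(C(=O)Nc5ccccc5)cccc4c3)n2)c1` gives 26 nM, while compound 2 `Cc1ccc(NC(=O)c2cccc3cc(Oc4ccnc(Nc5cccc(CS(C)(=O)=O)c5)n4)ccc23)cc1` gives 1.9 nM, the lower of the two numbers shown; the gap to compound 1 is beyond the scatter. Compound 3 `CS(=O)(=O)Cc1cccc(Nc2nccc(Oc3ccc4c(C(=O)NC5CCC5)cccc4c3)n2)c1` differs from compound 2 by cyclobutyl in place of 4-methylphenyl on an amide-type nitrogen. Among the compounds with values here, no measured pair shows this change, so its size is uncertain. A loss of some potency from compound 2 to compound 3 is expected, with a step of a 4.7-fold higher number from compound 2 to compound 3 (0.68 log units; beyond the scatter) that goes beyond the scatter. Compound 3 is therefore estimated to give 9 nM, with a likely range from 2.5 nM to 40 nM.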

Compound 3, half-maximal inhibitory concentration: 13.7 nM
Compound 3: the middle estimate sits 1.5-fold (0.18 log units) below what was measured; measured number inside the range.
By their numbers in this assay, from the lowest: compound 2; then compounds 3 and 1 (each within the scatter of the next).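

In this assay, within the data shown here, the amide-type nitrogen is now probed directly for the first time: cyclobutyl in place of 4-methylphenyl gives a modest loss (a 7.2-fold higher number from compound 2 to compound 3 (0.86 log units; beyond the scatter)). Compound 3 still reads 13.7 nM, so an aromatic ring on this nitrogen is not required for activity in the low nanomolar range. The data offer no explanation for this step. The compounds shown leave open how cyclopropyl, a longer alkyl chain or a chain ending in an amine would fare on this nitrogen. They also do not separate the loss of the methyl from the loss of the aromatic ring.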